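This account rests on a few compounds, and the source may have more. Where it says the series, first, only, none or still open, it means among the compounds named here.

Measured in an ADME assay on MT4 cells (Homo sapiens) for cytotoxicity, read by MTT assay; on this read-out lower numbers stand for higher toxicity in this test and higher numbers for lower toxicity in this test:
- compound 1 `COc1cc(OC)c2c(C(=O)/C=C(\O)C(=O)O)cn(Cc3ccc(F)cc3)c2c1`: 20700 nM
- compound 2 `CCOC(=O)/C(O)=C/C(=O)c1cn(Cc2ccc(F)cc2)c2cc(OC)cc(OC)c12`: 55400 nM

Of these two numbers, the lower belongs to compound 1, at 20700 nM, which makes it the more toxic of the pair in this assay. Going by the values given here, compound 2 is its only neighbour, and the gap is modest: a 2.7-fold higher number from compound 1 to compound 2 (0.43 log units; beyond the scatter).

Compound 3 `COc1cccc2c1c(C(=O)/C=C(\O)C(=O)O)cn2Cc1ccc(F)cc1` has not yet been measured. It differs from compound 1 in one place: hydrogen in place of methoxy on an aromatic carbon. In short, this is hydrogen in place of methoxy on an aromatic carbon.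

Among the compounds with values here, only one measured step is available as a guide, and it is an imperfect one. In a 2.7-fold higher number from compound 1 to compound 2 (0.43 log units; beyond the scatter), an ethyl replaces a hydrogen on an oxygen, which is a different kind of change at a different place. Within the data shown here, no measured step shows what removing a methoxy does. That single step does suggest that a small edit can shift this number only modestly, so no clear direction can be argued. The expected outcome is a 1.2-fold higher number from compound 1 to compound 3 (0.08 log units; within the scatter), probably no step beyond the scatter. For compound 3 the estimated value is 25000 nM, with an expected range from 9000 nM to 70000 nM.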

Compound 3, half-maximal cytotoxic concentration: 41100 nM
Estimate against measurement, compound 3: 1.6-fold (0.22 log units) below; the range from low to high includes it.
By their numbers in this assay, from the lowest: compounds 1, 3 and 2 (each within the scatter of the next, the first and the last beyond it).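

Going by these compounds alone, replacing the methoxy group on this aromatic carbon with hydrogen gives a 2.0-fold higher number from compound 1 to compound 3 (0.30 log units; within the scatter) in this assay and is the first measured change on the six-membered aromatic ring, since the earlier step concerned a hydrogen on an oxygen. Compound 3 thus shows that a methoxy group, with its 2 heavy atoms, can leave this carbon without a shift that stands clear of the usual scatter, so the number in this test does not depend on that group being present. Nothing measured here gives a reason for this result.

Still open, on these data alone, is how other groups would behave on this same carbon: an amine, a fluorine atom or a longer chain such as ethoxy could give a number close to these or far from them. Also open, as far as these compounds go, is whether the remaining methoxy group of compound 3 could be replaced by hydrogen with as small a step, and whether this same replacement would read the same way in the ethyl ester, compound 2.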